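Trimethoxyphenyl in place of fluorophenyl: working notes

This account rests on a few compounds, and the source may have more. Where it says the series, first, only, none or still open, it means among the compounds named here.

Values in a functional assay on HepG2 cells (Homo sapiens) for inhibition, read by MTT assay, with a stated time of 48 h (on this read-out lower numbers stand for stronger inhibition of growth and higher numbers for weaker inhibition of growth), follow.
Compound 1 `Cn1cc(C2CC(c3ccccc3)=NN2C(=O)c2cccnc2Cl)c2ccccc21` gives > 10000 nM (a limit of the assay)
Compound 2 `COc1cc(C2=NN(C(=O)c3ccc(C)nc3)C(c3cn(C)c4ccccc34)C2)cc(OC)c1OC` gives 310 nM
Compound 3 `Cn1cc(C2CC(c3ccc(F)cc3)=NN2C(=O)c2cccnc2)c2cc(Br)ccc21` gives 480 nM

Compound 3 stands within the scatter of compound 2, the nearest number. Compound 4 `COc1cc(C2=NN(C(=O)c3cccnc3)C(c3cn(C)c4ccc(Br)cc34)C2)cc(OC)c1OC` has 3,4,5-trimethoxyphenyl in place of 4-fluorophenyl on a carbon with a double bond to nitrogen. Within the data shown here, no measured pair isolates this change. Compound 2 also carries 3,4,5-trimethoxyphenyl and gives 310 nM while differing elsewhere from compound 4, so no shift beyond the scatter is expected in this assay and no firm direction is claimed. The expected move is a 1.5-fold lower number from compound 3 to compound 4 (0.18 log units; within the scatter) and remains an estimate. For compound 4 the estimated value is 320 nM (expected range 90 nM to 1200 nM).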

Compound 4, concentration for 50% growth inhibition: > 10000 nM
Compound 4 gave a limit, no number; the forecaster's own chance of this, stated with the estimate: 5%; middle value at least 31-fold (1.49 log units) from the limit.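

Putting 3,4,5-trimethoxyphenyl in place of 4-fluorophenyl on a carbon with a double bond to nitrogen gives an at least 20-fold higher number from compound 3 to compound 4 (1.31 log units; beyond the scatter) in this assay. Among these compounds, this is the first single-place step, and it shows that the group at this position can decide the read-out. The step is a bound and not a measured size, with compound 4 resting on a limit of the assay: the limit of > 10000 nM in this assay, at which 2 of the 4 values shown sit.

Open, going by these compounds, is whether a phenyl ring carrying a single methoxy group, or a morpholine, at this position would keep the value of compound 3. Also open, on these data alone, is whether the same change acts alike on other versions of the shared core.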